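This account rests on a few compounds, and the source may have more. Where it says the series, first, only, none or still open, it means among the compounds named here.

In a functional assay on BT-483 cells (Homo sapiens) for cytotoxicity, read by MTT assay, with a stated time of 24 h (on this read-out lower numbers stand for stronger inhibition and higher numbers for weaker inhibition), compound 1 (`CCNc1cc(-c2ccc(NC(=O)Nc3cccc(Cl)c3)cc2C)ccn1`) gives 16600 nM and compound 2 (`CCNc1cc(-c2ccc(NC(=O)Nc3ccc(C(F)(F)F)cc3)cc2C)ccn1`) gives 19700 nM, which amounts to a 1.2-fold higher number from compound 1 to compound 2 (0.07 log units; within the scatter). Compound 3 (`CCNc1cc(-c2ccc(NC(=O)Nc3c(C)cccc3C)cc2C)ccn1`) stands only at a limit, > 30000 nM, and not at a number. Compound 4 (`CCNc1cc(-c2ccc(NC(=O)Nc3ccccc3Cl)cc2C)ccn1`) has 2-chlorophenyl in place of 2,6-dimethylphenyl on an amide-type nitrogen. Among the compounds with values here, the steps that bear on this change are those that lead to the same 2,6-dimethylphenyl group, an at least 1.8-fold higher number from compound 1 to compound 3 (0.25 log units; that floor lies within the scatter) and an at least 1.5-fold higher number from compound 2 to compound 3 (0.18 log units; that floor lies within the scatter). Both are small, and their floors stay within the scatter. In this assay, a modest move towards a lower number is therefore expected, with the expected size being an at least 1.5-fold lower number from compound 3 to compound 4 (0.17 log units; that floor lies within the scatter). Compound 4 is estimated at 20000 nM, with an expected range of 11000 nM to 30000 nM.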

Compound 4, half-maximal inhibitory concentration: > 30000 nM
Compound 4 gave a limit, no number (the forecaster's own chance of this, stated with the estimate: 30%); middle value at least 1.5-fold (0.17 log units) away from the limit.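

In this assay, compound 4 with 2-chlorophenyl ends at a limit and not at a number, as compound 3 with 2,6-dimethylphenyl does, so the step between them cannot be read: the limit of > 30000 nM in this assay, at which 2 of the 4 values shown sit. Thus 2-chlorophenyl on this amide-type nitrogen gives no readable value in this assay, just as 2,6-dimethylphenyl does not. With 2-chlorophenyl in place of 3-chlorophenyl there is an at least 1.8-fold higher number from compound 1 to compound 4 (0.25 log units; that floor lies within the scatter), and with it in place of 4-(trifluoromethyl)phenyl there is an at least 1.5-fold higher number from compound 2 to compound 4 (0.18 log units; that floor lies within the scatter). As far as these compounds go, whether compound 3 and compound 4 truly differ stays open, as does whether 2-fluorophenyl or 2-methoxyphenyl on this nitrogen would give a number.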